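Benzyl for Cycloheptyl on a Urea Nitrogen in Two Cores

This account rests on a few compounds, and the source may have more. Where it says the series, first, only, none or still open, it means among the compounds named here.

Compound 1 `O=C(Nc1c(F)cc(F)cc1F)N(Cc1cccc(-c2cc[nH]n2)c1)C1CCCCCC1` gives 0.062 mg/kg in a functional assay on a cell-free system (plasma) with sterol O-acyltransferase, Soat (Rattus norvegicus) as the target; a higher number here means that more compound is needed for the effect, a lower number that less compound is needed.
Compound 2 `O=C(Nc1c(F)cc(F)cc1F)N(Cc1ccccc1)Cc1cccc(-c2cc[nH]n2)c1` gives 0.096 mg/kg in this assay.
Compound 3 `CSc1cc(C)nc(SC)c1NC(=O)N(Cc1ccc(-c2cnn(C)c2)cc1)C1CCCCCC1` gives only a limit of the assay, > 0.1 mg/kg, in this assay.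

In this assay one of the three values sits at the limit of > 0.1 mg/kg in this assay, at which 1 of the 3 values shown sits. From compound 1 to compound 2 the change is benzyl in place of cycloheptyl on an amide-type nitrogen, and the step is a 1.5-fold higher number from compound 1 to compound 2 (0.19 log units; within the scatter).

Compound 4 `CSc1cc(C)nc(SC)c1NC(=O)N(Cc1ccccc1)Cc1ccc(-c2cnn(C)c2)cc1` has not been measured. It differs from compound 3 by benzyl in place of cycloheptyl on an amide-type nitrogen, the same change as that between compound 1 and compound 2. How the core of compound 3 differs from the core of compound 1 is not broken down here.

Resting on the step of a 1.5-fold higher number from compound 1 to compound 2 (0.19 log units; within the scatter), which lies within the scatter, the expected step is a step that the limit leaves unreadable from compound 3 to compound 4. Compound 4 is therefore estimated at 0.2 mg/kg, most likely between 0.08 mg/kg and 0.6 mg/kg, and it may again return only a limit.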

Compound 4, dose for half-maximal effect: > 0.1 mg/kg
Compound 4: only a limit was reported (the forecaster's own chance of this, stated with the estimate: 70%); the middle value is on the limit's open side.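

The step between compound 3 and compound 4 cannot be read, since each gives only a limit: the limit of > 0.1 mg/kg in this assay, at which 2 of the 4 values shown sit.

From the compounds shown here alone, whether benzyl in place of cycloheptyl acts in the core of compound 3 as it does in the core of compound 1 stays open.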